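A Methyl Step Repeated on a Second Core

A few compounds are considered here, and "the series" means these few. Any claim that something is new, unique, unknown or untested is made for them only; others in the source may bear on it.

Compound 1, `CCNC(=O)Nc1cccc(S(=O)(=O)Oc2ccccc2C)c1`: 44000 nM
Compound 2, `CCNC(=O)Nc1cccc(S(=O)(=O)Oc2ccccc2CC)c1`: 33000 nM
Compound 3, `CCNC(=O)Nc1ccc(S(=O)(=O)Oc2ccccc2C)cc1`: 12000 nM

In a functional assay on HT-29 cells (Homo sapiens) for cytotoxicity, read by sulforhodamine B assay, with a stated time of 48 h (on this read-out lower numbers stand for stronger inhibition and higher numbers for weaker inhibition), these three compounds were compared. Compound 3 has the lowest number of the three, and its distance from both compound 1 and compound 2 lies beyond the scatter of repeated measurements. Compound 1 and compound 2 differ only by methyl in place of hydrogen on a saturated chain carbon bound to an aromatic carbon; that change gave a 1.3-fold lower number from compound 1 to compound 2 (0.12 log units; within the scatter), so the two cannot be ranked against each other. Compound 3 is built from the same atoms as compound 1, joined differently; the difference between the two cores is not broken down here.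

Compound 4, `CCNC(=O)Nc1ccc(S(=O)(=O)Oc2ccccc2CC)cc1`, has not yet been measured. It differs from compound 3 by methyl in place of hydrogen on a saturated chain carbon bound to an aromatic carbon, the same change that separates compound 1 from compound 2. The step from compound 3 to compound 4 is expected to be a 1.2-fold lower number from compound 3 to compound 4 (0.08 log units; within the scatter), because the matching pair showed a 1.3-fold lower number from compound 1 to compound 2 (0.12 log units; within the scatter); this rests on a single measured instance, so the expectation is loose. Compound 4 is therefore estimated at 10000 nM, with a likely range from 5000 nM to 20000 nM.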

Compound 4, half-maximal inhibitory concentration: 12000 nM
Compound 4: the middle estimate sits 1.2-fold (0.08 log units) below what was measured, and the stated range covers the measured number.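

In this assay, replacing hydrogen with methyl on the saturated chain carbon bound to an aromatic carbon, which turns 2-methylphenyl into 2-ethylphenyl, gave no change at the digits printed from compound 3 to compound 4 (within the scatter). Set beside the same change on the first core, the two steps cannot be told apart: the same change on two cores in this assay, a 1.3-fold lower number (0.12 log units; within the scatter) from compound 1 to compound 2 and no change at the digits printed (within the scatter) from compound 3 to compound 4, 1.3-fold (0.12 log units) apart, within the scatter of two such steps

Among the compounds shown here, this agreement shows only that the change made no readable difference on either of these two cores. Since both steps are small enough to be scatter, it does not show that a real effect carries over from one core to the other, and two cores say nothing about a third.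

The compounds shown carry only methyl and ethyl at this place, so it stays open whether a longer chain such as propyl, or an amine or a carboxylic acid, would give a step large enough to read. From the compounds shown here alone, it also stays open whether such a larger step would match on the two cores.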